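Amide variation on a shared aminoquinoline-phenyl core

This account rests on a few compounds, and the source may have more. Where it says the series, first, only, none or still open, it means among the compounds named here.

Measured so far:
compound 1 `Nc1cccc2c(-c3cccc(NC(=O)c4ccc(Cl)c(C(F)(F)F)c4)c3)ccnc12` — 3500 nM
compound 2 `Nc1cccc2c(-c3cccc(NC(=O)c4nccs4)c3)ccnc12` — 11300 nM
compound 3 `COc1ccc(C(=O)Nc2cccc(-c3ccnc4c(NC(C)=O)cccc34)c2)cc1OC` — 9400 nM

In a functional assay on SK-MEL-2 cells (Homo sapiens) for antiproliferative activity, read by sulforhodamine B assay, with a stated time of 48 h (a higher number here means a weaker inhibitor, a lower number a stronger inhibitor), compound 3 gives 9400 nM, the second highest of the three numbers. Compound 2 gives 11300 nM, which sits within the scatter of compound 3. Compound 1 gives 3500 nM, a lower number, and that gap lies beyond the scatter.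

Compound 4 `CC(=O)Nc1cccc2c(-c3cccc(NC(=O)c4ccc5c(c4)OCCO5)c3)ccnc12` is not yet measured. It differs from compound 3 by 2,3-dihydro-1,4-benzodioxin-6-yl in place of 3,4-dimethoxyphenyl on a carbonyl carbon. Within the data shown here, no measured pair shows this kind of change, so no step size can be read from the numbers. The expected step from compound 3 to compound 4 is a 1.2-fold lower number from compound 3 to compound 4 (0.07 log units; within the scatter), none beyond the scatter. For compound 4 the estimate is 8000 nM, within 3000 nM to 20000 nM.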

Compound 4, half-maximal inhibitory concentration: > 20000 nM
Compound 4: no number, only a limit; the forecaster's own chance of this, stated with the estimate: 10%; at least 2.5-fold (0.39 log units) between middle value and limit.
By their numbers in this assay, from the lowest: compound 1; then compounds 3 and 2 (each within the scatter of the next). At a limit, above all of these: compound 4.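

In this assay, compound 4 gives > 20000 nM, which is a limit of the assay and not a number. Among these compounds, this is the first one-place pair: 2,3-dihydro-1,4-benzodioxin-6-yl in place of 3,4-dimethoxyphenyl on a carbonyl carbon gives an at least 2.1-fold higher number from compound 3 to compound 4 (0.32 log units; beyond the scatter), although the heavy-atom and acceptor counts of the two groups match. The step is bounded on one side only: the limit of > 20000 nM in this assay, at which 1 of the 4 values shown sits.

Still open, on these data alone, is how a single methoxy group or a morpholine on the phenyl ring of compound 3 would read. Also open, as far as these compounds go, is whether the change reads the same with a free amine in place of the acetamide.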